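A few compounds are considered here, and "the series" means these few. Any claim that something is new, unique, unknown or untested is made for them only; others in the source may bear on it.

Compound 1 `COc1cc(-c2nn(-c3cccc(NC(=O)Nc4cc(C(F)(F)F)cc(C(F)(F)F)c4)c3)cc2-c2ccncc2)ccc1Cl` and compound 2 `COc1cc(-c2nn(-c3cccc(NC(=O)c4cccc(C(F)(F)F)c4)c3)cc2-c2ccncc2)ccc1Cl` share one core and differ only in the group on the carbonyl. In a functional assay on MCF7 cells (Homo sapiens) for inhibition, read by sulforhodamine B assay, with a stated time of 48 h (a lower number here means a stronger inhibitor of growth, a higher number a weaker inhibitor of growth), compound 1 gives 10900 nM. Compound 2 gives > 50000 nM, which is a limit of the assay and not a number. Compound 2 thus sits at the limit of > 50000 nM in this assay, at which 1 of the 2 values shown sits. Compound 3 `COc1cc(-c2nn(-c3cccc(NC(=O)Nc4ccc(Cl)c(Cl)c4)c3)cc2-c2ccncc2)ccc1Cl` has not been measured; it differs from compound 2 by (3,4-dichlorophenyl)amino in place of 3-(trifluoromethyl)phenyl on a carbonyl carbon. Compound 3 thereby carries a carbamoyl link, as compound 1 does. He expects an at least 3.3-fold lower number from compound 2 to compound 3 (0.52 log units; beyond the scatter), a gain beyond the scatter. For compound 3 he estimates 15000 nM, between 5000 nM and 50000 nM.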

Compound 3, concentration for total growth inhibition: > 50000 nM
Compound 3 was reported as a limit; the forecaster's own chance of this, stated with the estimate: 25%; at least 3.3-fold (0.52 log units) between middle value and limit.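

No step can be read from compound 2 to compound 3, because each result is a limit of the assay and not a number: the limit of > 50000 nM in this assay, at which 2 of the 3 values shown sit.

The compounds shown leave open whether (3,4-dichlorophenyl)amino in place of 3-(trifluoromethyl)phenyl on a carbonyl carbon changes growth inhibition at all.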